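The compounds below may be only part of what the source reports. "The series", "measured", "known", "first", "only" and "open" are said of these compounds alone.

Of the compounds shown here, two have been measured in an assay on isolated protein for activation of Nicotinamide phosphoribosyltransferase (Homo sapiens); a higher number here means that more compound is needed for the effect, a lower number that less compound is needed. Compound 1 `CCOC(=O)c1ccc(NC(=S)NCc2ccncc2)cc1` gives 9770 nM in this assay. Compound 2 `O=C(NCc1ccncc1)Nc1ccc(S(=O)(=O)NCc2ccccc2)cc1` gives 102 nM in this assay, the lower of the two numbers; compound 1 lies well above it, beyond the scatter of repeated measurements. Compound 3 `O=C(NCc1ccncc1)Nc1ccc(S(=O)(=O)c2ccc(Cl)cc2)cc1` has not yet been measured. Compared with compound 2, it carries 4-chlorophenyl in place of benzylamino on a sulfonyl sulfur. Within the data shown here, no measured pair here differs in only that one place, so there is no direct precedent for this change. The loss of the single hydrogen-bond donor on the sulfonyl group may cost some activity, but the rest of the molecule is unchanged. The expected change from compound 2 to compound 3 is a 2.9-fold higher number from compound 2 to compound 3 (0.47 log units; beyond the scatter), a modest rise that may still fall within the scatter. Compound 3 is estimated to give 300 nM in this assay, in a range from 60 nM to 1500 nM.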

Compound 3, half-maximal effective concentration: 126 nM
Beside the measured number, compound 3's estimate is 2.4-fold (0.38 log units) above it; low and high end bracket the measured number.
By their numbers in this assay, from the lowest: compounds 2 and 3 (each within the scatter of the next); then compound 1.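

In this assay, putting 4-chlorophenyl in place of benzylamino on the sulfonyl sulfur gives a 1.2-fold higher number from compound 2 to compound 3 (0.09 log units; within the scatter), so compound 2 and compound 3 cannot be told apart here. Among these compounds, this is the first pair to isolate a change at this position, and it shows that the number can hold when one aromatic group replaces another, even though benzylamino counts a hydrogen-bond donor and 4-chlorophenyl counts none. No supporting measurement explains this match.

The compounds shown leave open whether the chlorine matters, which plain phenyl on the sulfonyl sulfur would test, and whether a much smaller group such as methyl would do equally well. A carboxylic acid or an amine at this position would show how far this tolerance extends.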